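The source may report more compounds than this note shows. Statements on the series, on what has been measured and on what is new or still open speak of the compounds shown alone.

Of the compounds shown here, three sharing one core have been measured in a functional assay on the whole organism (blood, strain Wistar-Okamoto) with Rattus norvegicus as the target, with a stated time of 5 days; a higher number here means that more compound is needed for the effect, a lower number that less compound is needed. Compound 1 `CCC(CC)/N=C(\NC#N)Nc1ccncc1` gives 2.5 mg/kg. Compound 2 `CCC(/N=C(\NC#N)Nc1ccncc1)C(C)C` gives 5 mg/kg. Compound 3 `CC(/N=C(\NC#N)Nc1ccncc1)C1CC1` gives 3 mg/kg, the second highest of the three numbers, nearest to compound 1 and furthest from compound 2, with both gaps within the scatter. Compound 4 `N#CN/C(=N\C(C1CC1)C1CC1)Nc1ccncc1` has not been measured; it differs from compound 3 by cyclopropyl in place of methyl on a saturated chain carbon bound to a double-bonded nitrogen and a saturated ring carbon. Two measured steps change the group on the double-bonded nitrogen, a 1.2-fold higher number from compound 1 to compound 3 (0.08 log units; within the scatter) and a 1.7-fold lower number from compound 2 to compound 3 (0.22 log units; within the scatter), and one adds methyl in place of hydrogen, a 2.0-fold higher number from compound 1 to compound 2 (0.30 log units; within the scatter). All lie within the scatter, so no step beyond the scatter is expected in this assay. Compound 4 is therefore estimated at 3 mg/kg, ranging from 1.5 mg/kg to 6 mg/kg. This expectation amounts to no change at the digits printed from compound 3 to compound 4 (within the scatter).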

Compound 4, minimum effective dose: 10 mg/kg
For compound 4 the middle estimate is 3.3-fold (0.52 log units) below the measured one; the measured number lies above the stated range.
By their numbers in this assay, from the lowest: compounds 1, 3, 2 and 4 (each within the scatter of the next, the first and the last beyond it).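

In this assay, going by these compounds alone, cyclopropyl in place of methyl on a saturated chain carbon bound to a double-bonded nitrogen and a saturated ring carbon gives a 3.3-fold higher number from compound 3 to compound 4 (0.52 log units; beyond the scatter) and is the first single change here to exceed the scatter. This position therefore does not accept every exchange without consequence, although the earlier changes on the double-bonded nitrogen stayed within the scatter. Nothing available explains this step. On these data alone, whether a phenyl ring or a tert-butyl group in the same place would bring a similar step remains open.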